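A few compounds are considered here, and "the series" means these few. Any claim that something is new, unique, unknown or untested is made for them only; others in the source may bear on it.

Notes on the series, step from compound 1 to compound 4.

Compound 1 `CN1CCN(c2nc3ccccc3[nH]2)CC1` sits at a limit of a functional assay on ileum for inhibition of histamine H1 receptor (Cavia porcellus); on this read-out higher numbers stand for weaker inhibition and lower numbers for stronger inhibition: in this assay compound 1 gives > 3000 nM, which is a limit of the assay and not a number (the limit of > 3000 nM in this assay, at which 1 of the 3 values shown sits). Compound 2 `CCOCCn1c(N2CCNCC2)nc2ccccc21` gives 11 nM in this assay, and compound 3 `CCCN1CCN(c2nc3ccccc3n2CCOCC)CC1` gives 16 nM. Among the compounds with values here, the only step measured within one place is a 1.5-fold higher number from compound 2 to compound 3 (0.16 log units; within the scatter), so alkylation of the amine nitrogen in the ring leaves the read-out unchanged. Within the data shown here, compounds 2 and 3 both carry a substituent on the aromatic nitrogen that compound 1 lacks, and both lie far from the limit; no single-place step connects them to compound 1.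

Compound 4 `CCSCCn1c(N2CCN(C)CC2)nc2ccccc21` differs from compound 1 by 2-(ethylsulfanyl)ethyl in place of hydrogen on an aromatic nitrogen. Among the measured compounds shown here, no measured step covers this change directly. Given the values of compound 2 and compound 3 for substituted aromatic nitrogen, and the tolerated step a 1.5-fold higher number from compound 2 to compound 3 (0.16 log units; within the scatter) for the methyl-bearing amine nitrogen, compound 4 is expected to land well inside the measurable range, at an estimated 25 nM (range 6 nM to 120 nM), an expected step of an at least 120-fold lower number from compound 1 to compound 4 (2.07 log units; beyond the scatter).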

Compound 4, half-maximal inhibitory concentration: 19 nM
For compound 4 the middle estimate is 1.3-fold (0.12 log units) above the measured one; low and high end bracket the measured number.
By their numbers in this assay, from the lowest: compounds 2, 3 and 4 (each within the scatter of the next). At a limit, above all of these: compound 1.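

In this assay, the aromatic nitrogen now has its first single-place step: an at least 150-fold lower number from compound 1 to compound 4 (2.19 log units; beyond the scatter). The series thus links a substituent at this position, next to the ring atom that bears the 4-methylpiperazin-1-yl group, directly to a move from the limit into the measurable range, which compounds 2 and 3 could only suggest. The size of this step has only one firm end, since compound 1 stands at a limit and not at a number: the limit of > 3000 nM in this assay, at which 1 of the 4 values shown sits.

Compound 4 differs from compounds 2 and 3 in more than one place, so the contribution of the sulfur in the chain cannot be read from them. As far as these compounds go, how a plain ethyl, a benzyl group or a chain ending in a carboxylic acid would fare on this aromatic nitrogen remains open.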